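This account rests on a few compounds, and the source may have more. Where it says the series, first, only, none or still open, it means among the compounds named here.

Measured in a physicochemical assay for permeability, using PAMPA; on this read-out higher numbers stand for higher permeability and lower numbers for lower permeability:
- Compound 1 `O=C(O)CCn1c(=O)oc2cc(OCC3CCC3)c(Cl)cc21` gives 12 nm/s
- Compound 2 `CCc1cc2oc(=O)n(CCC(=O)O)c2cc1Cl` gives < 10 nm/s, a limit of the assay
- Compound 3 `O=C(O)CCn1c(=O)oc2cc(OCc3ccccn3)c(Cl)cc21` gives 11 nm/s

Compound 3 stands within the scatter of compound 1, with a 1.1-fold lower number from compound 1 to compound 3 (0.04 log units; within the scatter). Compound 4 `CCOc1cc2oc(=O)n(CCC(=O)O)c2cc1Cl` has methyl in place of pyridin-2-yl on a saturated chain carbon bound to an oxygen on an aromatic ring. Among the measured compounds shown here, two measured steps bear on this: a 1.1-fold lower number from compound 1 to compound 3 (0.04 log units; within the scatter) at the same place, and an at least 1.1-fold higher number from compound 2 to compound 3 (0.04 log units; that floor lies within the scatter). Neither shows a change beyond the scatter, although the second rests on a limit. In this assay the expected 1.1-fold lower number from compound 3 to compound 4 (0.04 log units; within the scatter) therefore stays within the scatter, close to the limit of < 10 nm/s in this assay, at which 1 of the 3 values shown sits. For compound 4 the estimated value is 10 nm/s, with an expected range from 6 nm/s to 18 nm/s.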

Compound 4, apparent permeability: < 10 nm/s
Compound 4: no number, only a limit; the forecaster's own chance of this, stated with the estimate: 45%; the middle value lies on the limit itself.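

Compound 4 gives only a limit in this assay, so methyl in place of pyridin-2-yl at this place yields floors and no sizes: an at least 1.1-fold lower number from compound 3 to compound 4 (0.04 log units; that floor lies within the scatter), and an at least 1.2-fold lower number from compound 1 to compound 4 (0.07 log units; that floor lies within the scatter). The step between compound 2 and compound 4 cannot be read, as both values are limits. Compound 4 joins compound 2 at that limit, while compound 1 and compound 3 give numbers, and the read-out leaves little room at this position: the limit of < 10 nm/s in this assay, at which 2 of the 4 values shown sit.

Going by these compounds, it remains open whether an amine or a longer chain at this place would move the number beyond the scatter.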